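Swapping a Butyl Chain for a Methylphenyl Ring

The compounds below may be only part of what the source reports. "The series", "measured", "known", "first", "only" and "open" are said of these compounds alone.

Compound 1 `CCCCNC(=O)c1c(O)c2cccnc2n(-c2ccccc2)c1=O` gives 12.8% in a functional assay on the whole organism for inhibition, with Rattus norvegicus as the target, read by paw edema, at a dose of 100 mg/kg by the oral route (on this read-out higher numbers stand for more inhibition at the one dose given (going by the name of the read-out) and lower numbers for less inhibition), the highest of the three numbers at hand. Compound 2 `O=C(Nc1ccc(Cl)cc1)c1c(O)c2cccnc2n(-c2ccccc2)c1=O` gives 11.6%, and compound 3 `Nc1ccc(NC(=O)c2c(O)c3cccnc3n(-c3ccccc3)c2=O)cc1` gives -5.5%. The step of a number 1.2 percentage points lower from compound 1 to compound 2 (within the scatter) shows that replacing the butyl chain with a plain aryl ring carrying chloro changes little, whereas a number 18.3 percentage points lower from compound 1 to compound 3 (beyond the scatter) and a number 17.1 percentage points lower from compound 2 to compound 3 (beyond the scatter) show that an aryl ring carrying amino lowers the read-out. Compound 4 `Cc1ccccc1NC(=O)c1c(O)c2cccnc2n(-c2ccccc2)c1=O` differs from compound 1 by 2-methylphenyl in place of butyl on an amide-type nitrogen. This resembles the step to compound 2 more than the step to compound 3, since the entering group carries no donor or acceptor, so for compound 4 a step of a number 2.8 percentage points lower from compound 1 to compound 4 (within the scatter) is expected. The value of compound 4 is estimated at 10%, with a range from 0% to 22%.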

Compound 4, a percentage reported as inhibition, in the whole organism at one dose (the size of the read-out at that dose, not a potency): 11.7%
Estimate against measurement, compound 4: 1.7 percentage points below; measured number inside the range.
By their numbers in this assay, from the lowest: compound 3; then compounds 2, 4 and 1 (each within the scatter of the next).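

In this assay, 2-methylphenyl on the amide-type nitrogen stands level with the butyl chain (a number 1.1 percentage points lower from compound 1 to compound 4 (within the scatter)) and with 4-chlorophenyl (a number 0.1 percentage points higher from compound 2 to compound 4 (within the scatter)). Within the data shown here, only 4-aminophenyl stands apart (a number 17.2 percentage points higher from compound 3 to compound 4 (beyond the scatter)), so a third group now matches butyl, and compound 3 remains the one compound that goes against this pattern. No measurement at hand gives a reason for it. As far as these compounds go, it remains open whether a ring carrying a carboxylic acid would fall with compound 3 or stay with compound 2, and whether a longer chain such as octyl would match butyl.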